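Compound 3 to compound 4: methoxy for ethyl

The source may hold more compounds than are shown below. What is called first, only, known or untested is meant among the compounds shown, and "the series" means these compounds.

In an ADME assay on microsomes from liver (Homo sapiens) for metabolic stability (on this read-out lower numbers stand for slow clearance and higher numbers for fast clearance), compound 1 (`CC(C)Oc1cc(Oc2ccc(S(C)(=O)=O)cc2)cc(-c2nccc(=O)[nH]2)c1`) gives < 9.8 mL/min/kg, which is a limit of the assay. Compound 2 (`Cc1cc(=O)[nH]c(-c2cc(Oc3ccc(S(C)(=O)=O)cc3)cc(OC(C)C)c2)n1`) gives < 8 mL/min/kg, also a limit. Compound 3 (`CCc1cnc(-c2cc(Oc3ccc(S(C)(=O)=O)cc3)cc(OC(C)C)c2)[nH]c1=O`) gives < 8 mL/min/kg, again a limit, so it has no exact number. The series therefore offers only the limit of < 8 mL/min/kg in this assay, at which 2 of the 3 values shown sit, and (the limit of < 9.8 mL/min/kg in this assay, at which 1 of the 3 values shown sits).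

Compound 4 (`COc1cnc(-c2cc(Oc3ccc(S(C)(=O)=O)cc3)cc(OC(C)C)c2)[nH]c1=O`) differs from compound 3 by one change: methoxy in place of ethyl on an aromatic carbon. In words, methoxy stands in place of ethyl on an aromatic carbon.

The nearest measured steps are a step that the two limits leave unreadable from compound 1 to compound 3, a step that the two limits leave unreadable from compound 1 to compound 2 and a step that the two limits leave unreadable from compound 2 to compound 3. None has a readable size, yet all three compounds end in limits, and the alkyl changes show no departure from that picture. No step beyond the usual scatter is therefore expected, and no direction is assumed. The expected step is a number no lower from compound 3 to compound 4 (the limit leaves the size open). A limit is the most likely report for compound 4. For compound 4 the estimated value is 8 mL/min/kg, with an expected range from 5 mL/min/kg to 15 mL/min/kg.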

Compound 4, clearance: < 8 mL/min/kg
Compound 4 gave a limit, no number; the forecaster's own chance of this, stated with the estimate: 70%; the middle value sits exactly at the limit.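

In this assay compound 4 gives < 8 mL/min/kg, a limit and not a number. Its steps from compound 1, compound 2 and compound 3 cannot be read. The compounds shown leave open whether hydrogen, methyl, ethyl and methoxy at this place differ at all on this read-out.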